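From 2-methylphenyl to 4-(tert-butyl)phenyl on the triazole

A few compounds are considered here, and "the series" means these few. Any claim that something is new, unique, unknown or untested is made for them only; others in the source may bear on it.

Measured compounds:
Compound 1, `C/C(=C\CC/C(C)=C/CC[C@@H]1[C@@]2(C)CCC(=O)C(C)(C)[C@H]2CC[C@@]1(C)O)CC/C=C(\C)C(=O)OCc1cn(C[C@@H]2O[C@H](n3ccc(=O)[nH]c3=O)C[C@H]2O)nn1`, 33100 nM
Compound 2, `C/C(=C\CC/C(C)=C/CC[C@@H]1[C@@]2(C)CCC(=O)C(C)(C)[C@H]2CC[C@@]1(C)O)CC/C=C(\C)C(=O)OCc1cn(-c2ccccc2C)nn1`, > 150000 nM

Two compounds carry the shared core of compound 1. In a functional assay on DU-145 cells (Homo sapiens) for antiproliferative activity, read by MTT assay, with a stated time of 48 h (on this read-out lower numbers stand for stronger inhibition and higher numbers for weaker inhibition), compound 1 gives 33100 nM. Compound 2 is measured only as a limit: in this assay compound 2 returns > 150000 nM, which is a bound of the assay rather than a number, as recorded by the limit of > 150000 nM in this assay, at which 1 of the 2 values shown sits. Compound 2 therefore stands at the limit of what this assay reports, and no finished number is available for it.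

Compound 3, `C/C(=C\CC/C(C)=C/CC[C@@H]1[C@@]2(C)CCC(=O)C(C)(C)[C@H]2CC[C@@]1(C)O)CC/C=C(\C)C(=O)OCc1cn(-c2ccc(C(C)(C)C)cc2)nn1`, differs from compound 2 by 4-(tert-butyl)phenyl in place of 2-methylphenyl on an aromatic nitrogen. Among the measured compounds shown here, no step between two measured compounds is available to anchor this change. The expectation is a step of no size beyond the scatter, a number no higher from compound 2 to compound 3 (the limit leaves the size open), with a fair chance that only a limit is reported again. Compound 3 is estimated at 150000 nM, in a range from 50000 nM to 300000 nM.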

Compound 3, half-maximal inhibitory concentration: > 150000 nM
Compound 3: no number, only a limit (the forecaster's own chance of this, stated with the estimate: 65%); the middle value lies on the limit itself.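

Compound 2 and compound 3 both end at a limit in this assay, not at a number, so no step can be read between them: the limit of > 150000 nM in this assay, at which 2 of the 3 values shown sit.

The compounds shown leave open whether 4-(tert-butyl)phenyl in place of 2-methylphenyl on an aromatic nitrogen changes the activity at all.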